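Ethynyl in place of furan-3-yl: working notes

This account rests on a few compounds, and the source may have more. Where it says the series, first, only, none or still open, it means among the compounds named here.

Measured in an ADME assay on BJ cells (Homo sapiens), read by MTT assay, with a stated time of 72 h; on this read-out lower numbers stand for stronger inhibition and higher numbers for weaker inhibition:
- compound 1 `C#Cc1cn([C@@H]2O[C@H](CO)[C@@H](O)[C@H]2O)c2ncnc(OC)c12`: 98400 nM
- compound 2 `Cc1ncnc2c1c(-c1ccoc1)cn2[C@@H]1O[C@H](CO)[C@@H](O)[C@H]1O`: 89200 nM

Compound 2 gives 89200 nM, which lies within the usual scatter of compound 1 at 98400 nM, so neither compound stands apart on these numbers. Going by the values given here, no measured pair differs in only one place, so no measured step is available as a guide.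

The next entry is compound 3 `C#Cc1cn([C@@H]2O[C@H](CO)[C@@H](O)[C@H]2O)c2ncnc(C)c12`, with ethynyl in place of furan-3-yl on an aromatic carbon. Compound 1 also carries ethynyl and gives 98400 nM, close to the other measured value. No change beyond the scatter is therefore expected in this assay. The estimated step of a 1.3-fold lower number from compound 2 to compound 3 (0.11 log units; within the scatter) is expected to remain within the scatter. For compound 3 the expected value is 70000 nM, with an estimated range of 20000 nM to 150000 nM.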

Compound 3, half-maximal inhibitory concentration: 50 nM
Compound 3: the middle estimate sits 1400-fold (3.15 log units) above what was measured; measured number below the stated range.
By their numbers in this assay, from the lowest: compound 3; then compounds 2 and 1 (each within the scatter of the next).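

In this assay, ethynyl in place of furan-3-yl on an aromatic carbon gives a 1800-fold lower number from compound 2 to compound 3 (3.25 log units; beyond the scatter), so this position on the five-membered aromatic ring responds strongly to the group it carries when methyl is present on the core. With ethynyl held fixed, methyl in place of methoxy gives a 2000-fold lower number from compound 1 to compound 3 (3.29 log units; beyond the scatter), so ethynyl does not bring a low number on its own, as compound 1 shows, and methyl does not do so with furan-3-yl, as compound 2 shows. No supporting data bear on the cause of either step.

The compounds shown leave open whether the low number depends on ethynyl itself or would also appear with a nitrile or a longer chain such as propynyl. They also leave open whether ethyl or an amine could stand in place of methyl and keep that number.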